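The compounds below may be only part of what the source reports. "The series", "measured", "known", "first", "only" and "open" are said of these compounds alone.

Compound 1 `O=C1O[C@H]([C@@H](O)Cn2cc(-c3ccc(Br)cc3)nn2)C(OCc2ccccc2)=C1OCc1ccccc1` and compound 3 `O=C1O[C@H]([C@@H](O)Cn2cc(-c3cccc(O)c3)nn2)C(OCc2ccccc2)=C1OCc1ccccc1` share one core and differ in a single place, the group on the ring at the far end. In a functional assay on MCF7 cells (Homo sapiens) for antiproliferative activity, read by MTT assay, with a stated time of 72 h (a lower number here means a stronger inhibitor, a higher number a weaker inhibitor), compound 1 gives 5620 nM, and compound 3 gives 51800 nM; this gives a 9.2-fold higher number from compound 1 to compound 3 (0.96 log units; beyond the scatter). Compound 2 `Cc1ccc(-c2cn(C/C=C3\OC(=O)C(OCc4ccccc4)=C3OCc3ccccc3)nn2)cc1` is built on a related but distinct core. In this assay compound 2 reaches only a limit of the assay, > 100000 nM, so no number is known for it, only that limit (the limit of > 100000 nM in this assay, at which 1 of the 3 values shown sits). Compound 4 `CCCCCc1ccc(-c2cn(C/C=C3\OC(=O)C(OCc4ccccc4)=C3OCc3ccccc3)nn2)cc1` differs from compound 2 in one place: butyl in place of hydrogen on a saturated chain carbon bound to an aromatic carbon. None of the measured steps covers this kind of change; the single step shown, a 9.2-fold higher number from compound 1 to compound 3 (0.96 log units; beyond the scatter), swaps one ring substituent for another on the other core and so offers no guide to the direction or size expected here. With compound 2 sitting at a limit, the expected step is an at least 1.2-fold lower number from compound 2 to compound 4 (0.09 log units; that floor lies within the scatter). Compound 4 is therefore estimated at 80000 nM, within a range from 15000 nM to 200000 nM, with a real chance that only a limit is reported again.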

Compound 4, half-maximal inhibitory concentration: > 100000 nM
Compound 4: no number, only a limit; the forecaster's own chance of this, stated with the estimate: 55%; middle value at least 1.2-fold (0.09 log units) away from the limit.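

Compound 2 and compound 4 each reach only a limit in this assay and give no number, so no step can be read between them: the limit of > 100000 nM in this assay, at which 2 of the 4 values shown sit. On these data alone, whether the change from 4-methylphenyl to 4-pentylphenyl shifts the value at all stays open.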